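Pyrimidinyl for fluoropyrimidinyloxy: expected cytotoxicity of compound 4

The compounds below may be only part of what the source reports. "The series", "measured", "known", "first", "only" and "open" are said of these compounds alone.

Of the compounds shown here, three sharing one core have been tested in a toxicity assay on HepG2 2.2.15 cells (Homo sapiens) for cytotoxicity, read by CellTiter-Glo; on this read-out higher numbers stand for lower toxicity in this test and lower numbers for higher toxicity in this test. Compound 1 `O=C(Nc1cc(F)c(F)c(F)c1)N1CCCn2ncc(N3CC(c4ccccc4)CC3=O)c2C1` gives only a limit of the assay, > 2000 nM, not a number. Compound 2 `O=C1CC(Oc2ncc(F)cn2)CN1c1cnn2c1CN(C(=O)Nc1cc(F)c(F)c(F)c1)C(C1CC1)C2` gives 96200 nM, and compound 3 `CC1CN(C(=O)Nc2cc(F)c(F)c(F)c2)Cc2c(N3CC(C#N)CC3=O)cnn21` gives 115000 nM. Of the two numbers, compound 2 has the lower one, but the gap to compound 3 lies within the usual scatter, so the two cannot be told apart in this assay.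

Compound 4 `O=C1CC(c2ncccn2)CN1c1cnn2c1CN(C(=O)Nc1cc(F)c(F)c(F)c1)C(C1CC1)C2` has not yet been measured. It differs from compound 2 in one place: pyrimidin-2-yl in place of (5-fluoropyrimidin-2-yl)oxy on a saturated ring carbon.

Among the compounds with values here, no measured pair differing in one place is available, so the size of this step cannot be read from earlier steps. Since the two numbers for compound 2 and compound 3 sit close together despite different groups at that carbon, the change a 1.1-fold lower number from compound 2 to compound 4 (0.03 log units; within the scatter) is expected to stay within the scatter, in no clear direction. Compound 4 is therefore expected to give about 90000 nM, in a range from 30000 nM to 200000 nM.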

Compound 4, half-maximal cytotoxic concentration: > 200000 nM
Compound 4 gave a limit, no number; the forecaster's own chance of this, stated with the estimate: 25%; middle value at least 2.2-fold (0.34 log units) away from the limit.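

At this saturated ring carbon of the five-membered non-aromatic ring, pyrimidin-2-yl in place of (5-fluoropyrimidin-2-yl)oxy gives an at least 2.0-fold higher number from compound 2 to compound 4 (0.31 log units; beyond the scatter) in this assay, which on this read-out means lower toxicity in this test. Within the data shown here, no earlier compound formed a one-place pair with another, so this is the first sign that the group on this carbon can shift the reading beyond the scatter. Compound 4 gives only a limit, and the full size of the step stays unknown because no number exists for it: the limit of > 200000 nM in this assay, at which 1 of the 4 values shown sits.

The compounds shown leave open whether the shift follows the loss of the oxygen link, the loss of the fluorine, or both, since this one step changes them together. Pyrimidin-2-yloxy or 5-fluoropyrimidin-2-yl on the same carbon would separate the two, while an amine there would show whether an aromatic ring is needed at all.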